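The source may hold more compounds than are shown below. What is called first, only, known or untested is meant among the compounds shown, and "the series" means these compounds.

In an ADME assay on NIH3T3 cells (Mus musculus) for cytotoxicity (a higher number here means that more compound is needed for the effect, a lower number that less compound is needed), compound 1 `Cc1ccccc1Oc1cccc(Cn2ccnc2)c1` gives 79300 nM and compound 2 `Cc1cc(Oc2cccc(Cn3ccnn3)c2)cc(C)c1Cl` gives 66800 nM, so these two values lie within the usual scatter of each other. Compound 3 `Cc1cc(Oc2cccc(Cn3ccc4ccccc43)c2)cc(C)c1Cl` gives > 100000 nM, which is a limit of the assay and not a number.

Compound 4 `Cc1nnc(Cc2cccc(Oc3cc(C)c(Cl)c(C)c3)c2)s1` has not yet been measured. It departs from compound 2 through one change, 5-methyl-1,3,4-thiadiazol-2-yl in place of 1H-1,2,3-triazol-1-yl on a saturated chain carbon bound to an aromatic carbon. Among the measured compounds shown here, no measured pair differs in one place only, so the expectation rests on the close values of the first two compounds, and no step beyond the scatter is expected. The expected change is a 1.1-fold lower number from compound 2 to compound 4 (0.05 log units; within the scatter). Compound 4 is expected at 60000 nM, within an estimated range of 28000 nM to 100000 nM.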

Compound 4, half-maximal effective concentration: 3800 nM
For compound 4 the middle estimate is 16-fold (1.20 log units) above the measured one; measured number below the stated range.
By their numbers in this assay, from the lowest: compound 4; then compounds 2 and 1 (each within the scatter of the next). At a limit, above all of these: compound 3.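

In this assay the group on a saturated chain carbon bound to an aromatic carbon proves to matter: 5-methyl-1,3,4-thiadiazol-2-yl in place of 1H-1,2,3-triazol-1-yl gives an 18-fold lower number from compound 2 to compound 4 (1.24 log units; beyond the scatter) and so less compound is needed for the effect. This is the first single change shown, and both groups are five-membered aromatic rings, so swapping one such ring for another is enough to move the number beyond the scatter. Nothing measured here explains the step.

Going by these compounds, the change alters the ring and adds a methyl at once, so which of the two carries the step stays open. On these data alone, how a simple amine in this place would read also stays open.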